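The source may report more compounds than this note shows. Statements on the series, on what has been measured and on what is new or still open speak of the compounds shown alone.

Measured compounds:
compound 1 `O=C(O)CN1C(=O)/C(=C/c2nc3ccccc3n2Cc2ccc(F)cc2)SC1=S` — 2620 nM
compound 2 `O=C(O)CN1C(=O)/C(=C/c2nc3ccccc3n2Cc2ccc(Cl)cc2)SC1=S` — 5580 nM
compound 3 `O=C(O)CN1C(=O)/C(=C/c2nc3cc(Cl)ccc3n2Cc2ccccc2F)SC1=S` — 1670 nM

Of the compounds shown here, three have been tested in a functional assay on MDA-MB-231 cells (Homo sapiens) for cytotoxicity, read by MTT assay, with a stated time of 48 h; on this read-out lower numbers stand for stronger inhibition and higher numbers for weaker inhibition. Compound 1 gives 2620 nM, and compound 2 gives 5580 nM. The two differ only by fluoro in place of chloro on an aromatic carbon, and that change produced a 2.1-fold lower number from compound 2 to compound 1 (0.33 log units; beyond the scatter). Compound 3 gives 1670 nM; its number lies within the scatter of compound 1 and beyond the scatter of compound 2. The difference between the cores of compound 2 and compound 3 is not broken down here.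

Compound 4 `O=C(O)CN1C(=O)/C(=C/c2nc3cc(F)ccc3n2Cc2ccccc2F)SC1=S` has not yet been measured in this assay. It differs from compound 3 by fluoro in place of chloro on an aromatic carbon. Within the data shown here, this is the same kind of change as the one from compound 2 to compound 1, not the same: there the place was para to a large group, whereas here it is on a ring that is part of a fused or bridged system of two rings, meta to a fused ring and para to a fused ring. Because a 2.1-fold lower number from compound 2 to compound 1 (0.33 log units; beyond the scatter) was seen for the earlier change, a modest step in the same direction is expected, a 1.5-fold lower number from compound 3 to compound 4 (0.18 log units; within the scatter). Compound 4 is therefore estimated to give 1100 nM, expected between 450 nM and 3000 nM.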

Compound 4, half-maximal inhibitory concentration: 22400 nM
Beside the measured number, compound 4's estimate is 20-fold (1.31 log units) below it, and the stated range ends below it.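

In this assay, fluoro in place of chloro on an aromatic carbon gave a 13-fold higher number from compound 3 to compound 4 (1.13 log units; beyond the scatter), a large step that runs against the direction of the earlier one. The two outcomes of this change do not agree: the same change on two cores in this assay, a 2.1-fold lower number (0.33 log units; beyond the scatter) from compound 2 to compound 1 and a 13-fold higher number (1.13 log units; beyond the scatter) from compound 3 to compound 4, 29-fold (1.46 log units) apart, beyond the scatter of two such steps This shows that, in this series, neither the size nor the direction of the change can be carried from one core to another, though it does not show why, as the two pairs differ both in the core and in the place of the change, and two pairs cannot separate these.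

The compounds shown leave open how a methyl or methoxy group on the same aromatic carbon of compound 4 would read, and so whether fluoro alone stands apart there. They also leave open whether the large step would persist if a methyl ester replaced the carboxylic acid shared by compound 3 and compound 4.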